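The source may hold more compounds than are shown below. What is called first, only, known or untested is meant among the compounds shown, and "the series" means these compounds.

Three compounds share one core. Compound 1 `C=C1C(=O)[C@]23C[C@@]1(O)CC[C@H]2c1ccc(O)c(C)c1[C@@H]3Cn1cc(-c2ccc(C(F)(F)F)cc2)nn1` in a functional assay on MCF7 cells (Homo sapiens) for cytotoxicity, read by MTT assay, with a stated time of 4 days (on this read-out higher numbers stand for weaker inhibition and lower numbers for stronger inhibition), gives 1840 nM, compound 2 `C=C1C(=O)[C@]23C[C@@]1(O)CC[C@H]2c1ccc(O)c(C)c1[C@@H]3Cn1cc(-c2ccc(C)cc2)nn1` gives 370 nM, and compound 3 `C=C1C(=O)[C@]23C[C@@]1(O)CC[C@H]2c1ccc(OS(=O)(=O)c2ccc(C)cc2)c(C)c1[C@@H]3Cn1cc(-c2ccc(C)cc2)nn1` gives 320 nM. Compound 2 stands second highest of the three numbers: its nearest neighbour is compound 3, and the two differ only within the scatter, since a 1.2-fold lower number from compound 2 to compound 3 (0.06 log units; within the scatter); its furthest is compound 1, because a 5.0-fold lower number from compound 1 to compound 2 (0.70 log units; beyond the scatter).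

Compound 4 `C=C1C(=O)[C@]23C[C@@]1(O)CC[C@H]2c1ccc(O)c(C)c1[C@@H]3Cn1cc(-c2ccc(Br)cc2)nn1` is not yet measured. It differs from compound 2 in one place: bromo in place of methyl on an aromatic carbon. Within the data shown here, the only measured step at that aromatic carbon is the one from trifluoromethyl to methyl, and there a 5.0-fold lower number from compound 1 to compound 2 (0.70 log units; beyond the scatter), a modest move. Bromo is a third group at that position with no direct precedent among these compounds, so a number somewhere between those of compound 2 and compound 1 seems the fairest expectation, with the uncertainty wide. Compound 4 is therefore estimated to give 700 nM in this assay, within a range of 250 nM to 2000 nM. The step expected from compound 2 to compound 4 is a 1.9-fold higher number from compound 2 to compound 4 (0.28 log units; within the scatter).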

Compound 4, half-maximal inhibitory concentration: 270 nM
For compound 4 the middle estimate is 2.6-fold (0.41 log units) above the measured one; the measured number falls inside the stated range.
By their numbers in this assay, from the lowest: compounds 4, 3 and 2 (each within the scatter of the next); then compound 1.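

In this assay, the change from 4-methylphenyl to 4-bromophenyl gives a 1.4-fold lower number from compound 2 to compound 4 (0.14 log units; within the scatter), so at this aromatic carbon, para to a large group, the read-out does not separate bromo from methyl. Of the three groups tried at this position, trifluoromethyl alone stands apart, and the replacement by bromo gives a 6.8-fold lower number from compound 1 to compound 4 (0.83 log units; beyond the scatter), so the earlier gap is not peculiar to methyl. Nothing measured here accounts for why trifluoromethyl differs from the other two groups.

The compounds shown leave open whether an amine, a carboxylic acid or a methoxy group on this aromatic carbon would read like methyl and bromo or like trifluoromethyl. They also leave open whether bromo would read the same with a (4-methylphenyl)sulfonyl group on the oxygen, as in compound 3.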